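The source may hold more compounds than are shown below. What is called first, only, known or untested is meant among the compounds shown, and "the series" means these compounds.

Measured compounds in a functional assay on HeLa cells (Homo sapiens) for cytotoxicity, read by MTT assay, with a stated time of 2 days, tested at 100 uM; a lower number here means a stronger effect, a higher number a weaker effect of the compound at the concentration tested:
compound 1 `COc1ccc(-c2cc(C(C)=O)c3[nH]c(-c4ccccc4)cc3c2)cc1` gives 21.1%;
compound 2 `COc1ccc(-c2cc(C(C)=O)c3[nH]c(-c4ccc(F)cc4)cc3c2)cc1` gives 20.6%.

On these two numbers compound 2 and compound 1 are not told apart, since the step of a number 0.5 percentage points lower from compound 1 to compound 2 (within the scatter) lies within the scatter. Compound 3 `CC(=O)c1cc(/C=C/c2ccc(F)cc2)cc2cc(-c3ccc(F)cc3)[nH]c12` differs from compound 2 at one place: 2-(4-fluorophenyl)ethenyl in place of 4-methoxyphenyl on an aromatic carbon. Among the measured compounds shown here, no measured step touches this exchange; the single step known, a number 0.5 percentage points lower from compound 1 to compound 2 (within the scatter), concerns a fluorine on the other ring and was within the scatter. With nothing pointing either way, compound 3 is expected near 25%, in a range from 5% to 60%. That means an expected step of a number 4.4 percentage points higher from compound 2 to compound 3 (within the scatter), not beyond the scatter.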

Compound 3, a percentage reported as activity, at one concentration (the size of the read-out at that concentration, not a potency): 20.3%
The estimate for compound 3 lay 4.7 percentage points above the measured number; measured number inside the range.
By their numbers in this assay, from the lowest: compounds 3, 2 and 1 (each within the scatter of the next).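

At the aromatic carbon para to a fused ring, 2-(4-fluorophenyl)ethenyl in place of 4-methoxyphenyl gives, in this assay, a number 0.3 percentage points lower from compound 2 to compound 3 (within the scatter). This is the first exchange shown at this position, and it indicates that the reading does not separate these two groups, even though the entering group brings a double bond outside aromatic rings and loses the oxygen. No available evidence bears on why the two readings cannot be told apart. From the compounds shown here alone, whether an amine or a carboxylic acid at this position would shift the reading remains open, as does the effect of replacing the acetyl group.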